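This account rests on a few compounds, and the source may have more. Where it says the series, first, only, none or still open, it means among the compounds named here.

Measured so far:
- Compound 1 `C=C(C)CNC(=S)Nc1cccc(C(F)(F)F)c1`; in an ADME assay on MT4 cells (Homo sapiens) for cytotoxicity (on this read-out lower numbers stand for higher toxicity in this test and higher numbers for lower toxicity in this test), compound 1 gives 43000 nM
- Compound 2 `CCCCc1ccc(NC(=S)Nc2cccc(C(F)(F)F)c2)c(C)c1`; in this assay compound 2 gives 43000 nM
- Compound 3 `O=[N+]([O-])c1ccc(NC(=S)Nc2cccc(C(F)(F)F)c2)cc1`; in this assay compound 3 gives 9200 nM

Compound 3 stands lowest of the three numbers, which here means the most toxic of the set; its gap to compound 1 and to compound 2 is the same and lies beyond the scatter, while compound 1 and compound 2 sit within the scatter of each other, so no order can be read between those two. Among the measured compounds shown here, no pair of measured compounds differs in a single place, so no step has been measured directly.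

Compound 4 `FC(F)(F)c1cccc(NC(=S)Nc2ccccc2)c1` differs from compound 3 as follows: hydrogen in place of nitro on an aromatic carbon. For the measured compounds named here, what can be said rests on the three numbers alone: the one compound carrying the nitro gives the low number, the two without it give the higher number. On that basis the change is expected to move the readout upward, toward the numbers of compound 1 and compound 2, with the step estimated at a 3.3-fold higher number from compound 3 to compound 4 (0.51 log units; beyond the scatter). Compound 4 is therefore estimated at 30000 nM, within a range of 12000 nM to 75000 nM.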

Compound 4, half-maximal cytotoxic concentration: 39000 nM
The estimate for compound 4 lay 1.3-fold (0.11 log units) below the measured number, within the range that was stated.
By their numbers in this assay, from the lowest: compound 3; then compounds 4, 1 and 2 (each within the scatter of the next).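

In this assay, hydrogen in place of nitro at this position, para to a large group, gives a 4.2-fold higher number from compound 3 to compound 4 (0.63 log units; beyond the scatter), so the low number of compound 3 now traces to the nitro through a single measured change rather than through a comparison of compounds differing in several places. Phenyl in place of 2-methylprop-2-en-1-yl on the amide-type nitrogen gives a 1.1-fold lower number from compound 1 to compound 4 (0.04 log units; within the scatter), so that exchange shows no readable change in this test. No data here give a reason for either step.

As far as these compounds go, whether the higher toxicity is particular to nitro remains open, as does what an amine, a nitrile or a carboxylic acid would give on the same aromatic carbon. Also open, from the compounds shown here alone, is whether nitro would give a similar step on another aromatic carbon of this ring.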